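Compound 3 to compound 4: cyclohexyl for cyclobutyl

The source may hold more compounds than are shown below. What is called first, only, known or untested is meant among the compounds shown, and "the series" means these compounds.

Among the compounds with values here, in an ADME assay on Vero cells (Chlorocebus sabaeus) for cytotoxicity, read by CellTiter-Glo, with a stated time of 72 h (a higher number here means that more compound is tolerated, a lower number that less compound is tolerated), compound 3 (`[O-][n+]1nc(NC2CCC2)[n+]([O-])c2ccc(F)cc21`) gives 1.6 ug/mL, the lowest of the three numbers so far. Compound 2 (`CCNc1n[n+]([O-])c2cc(F)ccc2[n+]1[O-]`) gives 4.6 ug/mL, and compound 1 (`[O-][n+]1nc(NC2CCCCC2)[n+]([O-])c2ccccc21`) gives 8.9 ug/mL.

Compound 4 (`[O-][n+]1nc(NC2CCCCC2)[n+]([O-])c2ccc(F)cc21`) has cyclohexyl in place of cyclobutyl on a nitrogen on an aromatic ring.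

Within the data shown here, only one measured step bears directly on this place: a 2.9-fold lower number from compound 2 to compound 3 (0.46 log units; beyond the scatter), a modest drop with cyclobutyl in place of ethyl. Taken alone, it points to a further small fall in this assay. Against that, compound 1 also carries cyclohexyl and stands high at 8.9 ug/mL, though no measured step isolates that group. The two hints oppose each other, so no clear direction is expected, and any change is expected to stay within the scatter.

The expected move is a 1.3-fold higher number from compound 3 to compound 4 (0.10 log units; within the scatter). In this assay the estimate for compound 4 is 2 ug/mL, with an expected range of 0.7 ug/mL to 6 ug/mL.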

Compound 4, half-maximal cytotoxic concentration: < 2.5 ug/mL
Compound 4 ended at the assay's limit; the forecaster's own chance of this, stated with the estimate: 3%; the middle value does not contradict the limit.
By their numbers in this assay, from the lowest: compound 3; then compounds 2 and 1 (each within the scatter of the next).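

Compound 4 stands at a limit of this assay, and the step from compound 3 cannot be read: the limit of < 2.5 ug/mL in this assay, at which 1 of the 4 values shown sits.

Fluoro in place of hydrogen on an aromatic carbon gives an at least 3.5-fold lower number from compound 1 to compound 4 (0.55 log units; beyond the scatter), so the high number of compound 1 does not carry over to compound 4. Cyclohexyl in place of ethyl on a nitrogen on an aromatic ring gives an at least 1.8-fold lower number from compound 2 to compound 4 (0.26 log units; that floor lies within the scatter), and that floor alone does not establish a real drop.

Where compound 4 lies relative to compound 3 remains open, so the order of cyclobutyl and cyclohexyl is unresolved. Also open, as far as these compounds go, is whether a carboxylic acid or a longer chain carrying an amine on that nitrogen would raise the number in this assay.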